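A 2,6-Difluorophenyl Variant in an Antiproliferative Triazole Series

This account rests on a few compounds, and the source may have more. Where it says the series, first, only, none or still open, it means among the compounds named here.

Compound 1 `N#CC1=C(N)Oc2c(N)cc3nc4ccccc4nc3c2C12C(=O)N(Cc1cnnn1-c1ccc(F)cc1)c1ccccc12` gives > 50000 nM in an ADME assay on HUVEC cells (Homo sapiens) for antiproliferative activity, read by MTT assay, with a stated time of 48 h (on this read-out lower numbers stand for stronger inhibition and higher numbers for weaker inhibition), which is a limit of the assay and not a number.
Compound 2 `COc1ccccc1-n1nncc1CN1C(=O)C2(C(C#N)=C(N)Oc3c(N)cc4nc5ccccc5nc4c32)c2ccccc21` gives > 50000 nM in this assay, again a limit.
Compound 3 `CCc1cccc(C)c1-n1nncc1CN1C(=O)C2(C(C#N)=C(N)Oc3c(N)cc4nc5ccccc5nc4c32)c2ccccc21` gives > 50000 nM in this assay, also a limit.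

Going by the values given here, compound 3 therefore stands exactly where the other two stand: every value so far is a limit, and no measured step in this set has a readable size. The three exchanges of the group on the aromatic nitrogen come out as a step that the two limits leave unreadable from compound 1 to compound 2, a step that the two limits leave unreadable from compound 1 to compound 3 and a step that the two limits leave unreadable from compound 2 to compound 3. Among the compounds with values here, the one piece of evidence that bears on all of them is the limit of > 50000 nM in this assay, at which 3 of the 3 values shown sit.

The change to compound 4 `N#CC1=C(N)Oc2c(N)cc3nc4ccccc4nc3c2C12C(=O)N(Cc1cnnn1-c1c(F)cccc1F)c1ccccc12` is 2,6-difluorophenyl in place of 2-ethyl-6-methylphenyl on an aromatic nitrogen. Within the data shown here, the steps that bear on it are these three exchanges of the group on the aromatic nitrogen, none of which gave a readable size. Nothing in the set points in either direction, so no step beyond the scatter in this assay is expected, and compound 4 is expected to sit at the limit as well. The estimate for compound 4 is 60000 nM, with an expected range from 20000 nM to 200000 nM. That expectation corresponds to a step that the limit leaves unreadable from compound 3 to compound 4.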

Compound 4, half-maximal inhibitory concentration: > 50000 nM
Compound 4 gave a limit, no number; the forecaster's own chance of this, stated with the estimate: 85%; the middle value is on the limit's open side.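

Compound 4 gives > 50000 nM in this assay, which is again a limit of the assay and not a number. Its steps from compound 1, compound 2 and compound 3 therefore cannot be read. The compounds shown leave open whether the group on the aromatic nitrogen changes the activity at all, and the only evidence that bears on this is a single shared limit: the limit of > 50000 nM in this assay, at which 4 of the 4 values shown sit.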